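A methyl added to the phenylsulfonyl compound

The source may hold more compounds than are shown below. What is called first, only, known or untested is meant among the compounds shown, and "the series" means these compounds.

Measured in a functional assay on HeLa cells (Homo sapiens) for antiproliferative activity, read by MTT assay, with a stated time of 24 h; a lower number here means a stronger inhibitor, a higher number a weaker inhibitor:
Compound 1 `Cc1ccc(-c2nn(-c3ccccc3)cc2-c2nc3ccccc3[nH]2)cc1`: 4950 nM
Compound 2 `FC(F)(F)c1ccc(-c2nn(-c3ccccc3)cc2-c2nc3ccccc3[nH]2)cc1`: 4670 nM
Compound 3 `Cc1ccc(-c2nn(-c3ccccc3)cc2-c2nc3ccccc3n2S(=O)(=O)c2ccccc2)cc1`: 820 nM

Of these three, compound 3 has the lowest number at 820 nM, clearly separated from both compound 1 and compound 2. The next compound, compound 4 `Cc1ccc(-c2nn(-c3ccccc3)cc2-c2nc3ccccc3n2S(=O)(=O)c2ccc(C)cc2)cc1`, has not yet been measured in this assay. It differs from compound 3 by a single change: methyl in place of hydrogen on an aromatic carbon. This is methyl in place of hydrogen on an aromatic carbon, which turns phenylsulfonyl into (4-methylphenyl)sulfonyl.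

For the measured compounds named here, no measured step makes this exact change, so the evidence is indirect. The step of a 6.0-fold lower number from compound 1 to compound 3 (0.78 log units; beyond the scatter) shows that adding phenylsulfonyl in place of hydrogen on an aromatic nitrogen moved the number beyond the scatter, but compound 4 keeps that group. The closest step in kind is a 1.1-fold lower number from compound 1 to compound 2 (0.03 log units; within the scatter), trifluoromethyl in place of methyl on an aromatic carbon. It stayed within the scatter, though it lies at a different place in the molecule. On this basis, the expected step is small: a 1.1-fold lower number from compound 3 to compound 4 (0.04 log units; within the scatter), with no change expected beyond the scatter.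

For compound 4 the estimated value is 750 nM, with an expected range from 320 nM to 1800 nM.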

Compound 4, half-maximal inhibitory concentration: 480 nM
Compound 4: middle estimate off by 1.6-fold (0.19 log units), on the high side; the measured number falls inside the stated range.
By their numbers in this assay, from the lowest: compounds 4 and 3 (each within the scatter of the next); then compounds 2 and 1 (each within the scatter of the next).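

In this assay, the methyl on the aromatic carbon of the sulfonyl's outer ring, para to a large group, gives a 1.7-fold lower number from compound 3 to compound 4 (0.23 log units; within the scatter) and so leaves compound 3 and compound 4 indistinguishable; this position accepts that one added carbon without a change that can be told from the scatter. The earlier compounds had shown the effect of a sulfonyl group on the aromatic nitrogen only for unsubstituted phenylsulfonyl, whereas a 10-fold lower number from compound 1 to compound 4 (1.01 log units; beyond the scatter) shows that (4-methylphenyl)sulfonyl also carries the number beyond the scatter, so the effect seen in a 6.0-fold lower number from compound 1 to compound 3 (0.78 log units; beyond the scatter) is not confined to the unsubstituted phenyl ring. No measurement among these compounds accounts for the effect of either sulfonyl group or for the tolerance of the added methyl.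

Among the compounds shown, methyl is the only group on this ring, so it remains open how an amine or a carboxylic acid at the same carbon would behave. On these data alone, it also remains open whether the sulfonyl link itself matters, since a benzoyl or a benzyl group on the aromatic nitrogen does not appear in this set.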